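A few compounds are considered here, and "the series" means these few. Any claim that something is new, unique, unknown or untested is made for them only; others in the source may bear on it.

Three compounds have a reading in a functional assay on NCI-H226 cells (Homo sapiens) for cytotoxicity, read by sulforhodamine B assay, with a stated time of 48 h, tested at 0.01 uM; a lower number here means a stronger effect, a higher number a weaker effect of the compound at the concentration tested:

compound 1 `COc1cc(-c2cc(/C=C/C(=O)c3ccc(N)cc3)[nH]n2)cc(OC)c1OC` gives 92%
compound 2 `COc1ccc(-c2cc(/C=C/C(=O)c3ccc(OC)c(OC)c3)[nH]n2)cc1` gives 83%
compound 3 `COc1ccc(C(=O)/C=C/c2cc(-c3cc(OC)c(OC)c(OC)c3)n[nH]2)cc1` gives 99%

For the measured compounds named here, compound 3 holds the highest of the three numbers; compound 1 sits nearest, and the only single change that was measured, a number 7 percentage points higher from compound 1 to compound 3 (within the scatter), stays within the scatter. Compound 2 differs in more than one place and its lower number is all that can be said of that pair. Compound 4 `COc1cc(-c2cc(/C=C/C(=O)c3ccc(F)c(F)c3)[nH]n2)cc(OC)c1OC` carries 3,4-difluorophenyl in place of 4-methoxyphenyl on a carbonyl carbon. Going by the values given here, no measured step replaces a 4-methoxyphenyl with a 3,4-difluorophenyl on a carbonyl carbon, so no step in this assay speaks to the change. Compound 4 is therefore expected to stay close to compound 3, with a number 7 percentage points lower from compound 3 to compound 4 (within the scatter) expected, and an estimate of 92%, ranging from 78% to 104%.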

Compound 4, a percentage reported as activity, at one concentration (the size of the read-out at that concentration, not a potency): 99%
Beside the measured number, compound 4's estimate is 7 percentage points below it, within the range that was stated.
By their numbers in this assay, from the lowest: compounds 2, 1, 3 and 4 (each within the scatter of the next, the first and the last beyond it).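

On this carbonyl carbon, 4-methoxyphenyl and 3,4-difluorophenyl read alike in this assay, with no change at the digits printed from compound 3 to compound 4 (within the scatter). Putting 3,4-difluorophenyl in place of 4-aminophenyl gives a number 7 percentage points higher from compound 1 to compound 4 (within the scatter), so all three groups tried at this carbon, on the same remaining structure, lie within the scatter of one another. Nothing available explains this likeness.

On these data alone, whether a carboxylic acid or a saturated amine at this carbon would move the reading beyond the scatter remains open. So does whether these three groups would still read alike at higher concentrations.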